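The source may report more compounds than this note shows. Statements on the series, on what has been measured and on what is new or still open speak of the compounds shown alone.

Working notes on the series. Compound 1 `COc1ccc(-c2cc(/C=C/C(=O)c3ccc(N)cc3)[nH]n2)cc1` and compound 2 `COc1cc(-c2cc(/C=C/C(=O)c3ccc(N)cc3)[nH]n2)cc(OC)c1OC` share one core and differ in the methoxy substitution of the aryl ring on the pyrazole side. In a functional assay on KM12 cells (Homo sapiens) for inhibition, read by sulforhodamine B assay, with a stated time of 48 h (a lower number here means that less compound is tolerated, a higher number that more compound is tolerated), compound 1 gives 7610 nM, and in this assay compound 2 gives 7270 nM. For the measured compounds named here, no step between the two is worked out here; what the two numbers show is that they sit within the scatter of one another, so compound 2 stands level with compound 1 on the numbers in hand, and neither can be set above the other.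

Compound 3 `COc1ccc(-c2cc(/C=C/C(=O)c3ccc(N)cc3)[nH]n2)cc1OC` is the next member and is still to be measured in this assay. It differs from compound 2 by hydrogen in place of methoxy on an aromatic carbon. The two measured compounds suggest that moving methoxy groups on this ring in this fashion leaves the read-out roughly where it is, so for the change from compound 2 to compound 3 no shift beyond the scatter is expected in this assay, in either direction. Compound 3 is therefore expected to come out near 7400 nM, with a range from 3500 nM to 16000 nM, which corresponds to an expected step of a 1.0-fold higher number from compound 2 to compound 3 (0.01 log units; within the scatter).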

Compound 3, concentration lethal to 50% of the cells: 6670 nM
Compound 3: the middle estimate sits 1.1-fold (0.05 log units) above what was measured; the range from low to high includes it.
By their numbers in this assay, from the lowest: compounds 3, 2 and 1 (each within the scatter of the next).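

In this assay compound 3 breaks the comparison of compound 1 and compound 2, which was not a single change, into two steps that each touch one place: hydrogen in place of methoxy (a 1.1-fold lower number from compound 2 to compound 3 (0.04 log units; within the scatter)) and methoxy in place of hydrogen (a 1.1-fold lower number from compound 1 to compound 3 (0.06 log units; within the scatter)). Both steps lie within the scatter, so at the aromatic carbon ortho to a methoxy group and meta to a large group, methoxy and hydrogen cannot be told apart by this read-out, and the same holds for the methoxy change that links compound 1 to compound 3. Nothing measured alongside these numbers bears on the result.

The compounds shown carry only methoxy or hydrogen on this ring, so it remains open whether a hydroxy group, a fluorine atom, an amine or a longer chain such as ethoxy at the same carbon would leave the read-out within the scatter. Also open, from the compounds shown here alone, is how the read-out behaves when this aryl ring carries no methoxy group at all.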